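A Methyl Group Added to the Only Numbered Compound

A few compounds are considered here, and "the series" means these few. Any claim that something is new, unique, unknown or untested is made for them only; others in the source may bear on it.

Among the measured compounds shown here, compound 3 `CCc1ccccc1-n1nncc1CN1C(=O)C2(C(C#N)=C(N)Oc3c(N)cc4nc5ccccc5nc4c32)c2ccccc21` is the single member of this small set that yields an actual number: in an ADME assay on L02 cells (Homo sapiens) for antiproliferative activity, read by MTT assay, with a stated time of 48 h (a higher number here means a weaker inhibitor, a lower number a stronger inhibitor), compound 3 gives 22900 nM. The other two compounds report only limits of the assay. Compound 1 `N#CC1=C(N)Oc2c(c3nc4ccccc4nc3c3ccccc23)C12C(=O)N(Cc1cnnn1-c1ccc(N)cc1)c1ccccc12` reaches a limit, > 50000 nM. Compound 2 `Cc1ccc(Cl)cc1-n1nncc1CN1C(=O)C2(C(C#N)=C(N)Oc3c2c2nc4ccccc4nc2c2ccccc32)c2ccccc21` likewise reaches a limit, > 50000 nM. The step between them, a step that the two limits leave unreadable from compound 1 to compound 2, thus has no readable size, and the standing of compound 3 among its neighbours rests on (the limit of > 50000 nM in this assay, at which 2 of the 3 values shown sit).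

Compound 4 `CCc1cccc(C)c1-n1nncc1CN1C(=O)C2(C(C#N)=C(N)Oc3c(N)cc4nc5ccccc5nc4c32)c2ccccc21` is the compound still to be measured. It differs from compound 3 in one place: methyl in place of hydrogen on an aromatic carbon. For the measured compounds named here, none of the measured steps concerns a methyl in place of hydrogen on an aromatic carbon, and the one step that exists is unreadable, so there is nothing here to give this change a direction. The expectation is therefore a step within the scatter, a 1.1-fold higher number from compound 3 to compound 4 (0.04 log units; within the scatter), as the estimated outcome. Compound 4 is accordingly estimated at 25000 nM in this assay, with an expected range from 9000 nM to 60000 nM, and a real chance that the assay once more returns only a limit.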

Compound 4, half-maximal inhibitory concentration: > 50000 nM
Compound 4 gave a limit, no number; the forecaster's own chance of this, stated with the estimate: 30%; at least 2.0-fold (0.30 log units) between middle value and limit.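

In this assay, among the compounds shown here, the change from 2-ethylphenyl to 2-ethyl-6-methylphenyl gives an at least 2.1-fold higher number from compound 3 to compound 4 (0.33 log units; beyond the scatter), and this is the first step in the set whose direction can be read. The value of compound 4 is a limit of the assay, so this step gives only a minimum and not a true size. For the compounds shown here, it does show that a single added methyl, on an aromatic carbon ortho to a large group, is enough to take the only numbered compound out of the measurable range, leaving the limit as the usual result in this small set: the limit of > 50000 nM in this assay, at which 3 of the 4 values shown sit.

On these data alone, how far compound 4 lies past its limit stays unknown, and the other step, which joins two limits, cannot be read either. The compounds shown also leave open whether a smaller or different group at this same place, such as fluorine or a methoxy group, would keep a readable number, and whether the result holds for this methyl alone or for any group placed there.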